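This account rests on a few compounds, and the source may have more. Where it says the series, first, only, none or still open, it means among the compounds named here.

In an ADME assay on Ava5 cells (Homo sapiens) for cytotoxicity (a higher number here means that more compound is tolerated, a lower number that less compound is tolerated), compound 1, `NC(=S)Nc1cccc(Oc2ccccc2)c1`, gives > 50000 nM, which is a limit of the assay rather than a number. Compound 2, `NC(=S)Nc1cccc(OCCCCc2ccccc2)c1`, likewise gives > 50000 nM in this assay, again a limit. For the measured compounds named here, compound 3, `NC(=S)Nc1cccc(OCCCCCc2ccccc2)c1`, is the one compound of the three with a number in this assay, 22000 nM, so it stands alone. Going by the values given here, the sole measured step, an at least 2.2-fold lower number from compound 2 to compound 3 (0.35 log units; beyond the scatter), carried the value away from the limit of > 50000 nM in this assay, at which 2 of the 3 values shown sit, and because of that limit its true size can only be given as a lower bound.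

Compound 4, `NC(=S)Nc1cccc(OCCCCCCCc2ccccc2)c1`, has not yet been measured in this assay. It differs from compound 3 by phenethyl in place of phenyl on a saturated chain carbon, five bonds along the chain from an oxygen on an aromatic ring. The measured step lengthened the saturated chain between the aromatic oxygen and the terminal ring and lowered the number by at least a modest amount; the change from compound 3 to compound 4 lengthens the same chain further. Among the compounds with values here, with only that one step to go on, a further decrease in this assay is expected, of similar or somewhat larger size, a 2.2-fold lower number from compound 3 to compound 4 (0.34 log units; beyond the scatter). Compound 4 is therefore estimated at 10000 nM, with a range from 4000 nM to 25000 nM.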

Compound 4, half-maximal cytotoxic concentration: 23000 nM
Compound 4: middle estimate off by 2.3-fold (0.36 log units), on the low side, and the stated range covers the measured number.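

At this place, on a saturated chain carbon, five bonds along the chain from an oxygen on an aromatic ring, the change to phenethyl, with 8 heavy atoms against the 6 of phenyl, gives a 1.0-fold higher number from compound 3 to compound 4 (0.02 log units; within the scatter), so the two compounds cannot be told apart in this assay. For the compounds shown here, the one earlier step, an at least 2.2-fold lower number from compound 2 to compound 3 (0.35 log units; beyond the scatter), had suggested that a longer chain goes with a lower number, but this pair does not follow that, and the pattern therefore does not hold beyond that single step. This is also the first step with a number at both ends, whereas the earlier step could be given only as a lower bound because it starts from a limit: the limit of > 50000 nM in this assay, at which 2 of the 4 values shown sit.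

The compounds shown leave open whether a longer chain than that of compound 4 would stay within the scatter of compound 3 and compound 4 or would depart from them. They also leave open how an amine or a carboxylic acid in place of the phenyl would read in this assay, and how far above the limit compound 1 and compound 2 truly lie.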